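Swapping the Tetrazole Arm for a Pyrimidine

The compounds below may be only part of what the source reports. "The series", "measured", "known", "first", "only" and "open" are said of these compounds alone.

Of the compounds shown here, three sharing one core have been tested in a functional assay on C6 cells (Rattus norvegicus) for cytotoxicity, read by MTT assay, with a stated time of 24 h; a lower number here means a stronger inhibitor, a higher number a weaker inhibitor. Compound 1 `Cc1ccc(-c2cs/c(=N/NC(=O)CSc3nnnn3-c3ccccc3)n2-c2ccccc2)cc1` gives 14.7 ug/mL. Compound 2 `O=C(CSc1nnnn1-c1ccccc1)N/N=c1/scc(-c2ccc(F)cc2)n1-c1ccccc1` gives 24.3 ug/mL, and compound 3 `O=C(CSc1nnnn1-c1ccccc1)N/N=c1/scc(-c2ccccc2)n1-c1ccccc1` gives 8.3 ug/mL. For the measured compounds named here, compound 1 thus stands second highest of the three numbers, with a 1.7-fold higher number from compound 1 to compound 2 (0.22 log units; within the scatter) and a 1.8-fold lower number from compound 1 to compound 3 (0.25 log units; within the scatter); only the step of a 2.9-fold lower number from compound 2 to compound 3 (0.47 log units; beyond the scatter) lies beyond the scatter. Compound 4 `Cc1ccc(-c2cs/c(=N/NC(=O)CSc3ncccn3)n2-c2ccccc2)cc1` differs from compound 1 in a single place: pyrimidin-2-yl in place of 1-phenyl-1H-tetrazol-5-yl on a sulfur. Going by the values given here, each of the three measured steps changes a group on an aromatic carbon in another part of the core, and none of them alters the group attached to the sulfur, so no measured step bears directly on this change. Going by these compounds, with nothing in the measured set pointing either way, the step of a 1.0-fold higher number from compound 1 to compound 4 (0.01 log units; within the scatter) is expected to stay within the usual scatter, and the range is kept wide to reflect that the sulfur-bound group is untested. Compound 4 is therefore estimated at 15 ug/mL, with a range from 6 ug/mL to 40 ug/mL.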

Compound 4, half-maximal inhibitory concentration: 85 ug/mL
Estimate against measurement, compound 4: 5.7-fold (0.75 log units) below; the measured number lies above the stated range.
By their numbers in this assay, from the lowest: compounds 3, 1 and 2 (each within the scatter of the next, the first and the last beyond it); then compound 4.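

The group on the sulfur clearly matters in this assay: pyrimidin-2-yl in place of 1-phenyl-1H-tetrazol-5-yl gives a 5.8-fold higher number from compound 1 to compound 4 (0.76 log units; beyond the scatter), a larger step than any of the earlier changes on an aromatic carbon. This single swap changes several things at once, as the entering group has fewer heavy atoms, fewer hydrogen-bond acceptors and one ring rather than two, so the step cannot show which difference counts. Nothing measured here explains the step.

Going by these compounds, it remains open whether the loss of the phenyl ring or the replacement of the tetrazole ring drives the change, which a 1-methyl-1H-tetrazol-5-yl group on the sulfur could help to separate. On these data alone, it is also open whether pyrimidin-2-yl would have the same effect with hydrogen or fluoro in place of the methyl of compound 1.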